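Removing the chloro group from compound 1

A few compounds are considered here, and "the series" means these few. Any claim that something is new, unique, unknown or untested is made for them only; others in the source may bear on it.

Compound 1 `COc1ccc(C2CC(Nc3nc4ccc(Cl)cc4s3)=NN2C(C)=O)cc1O`: 127 umol/kg
Compound 2 `CC(=O)N1N=C(Nc2nc3ccc(Cl)cc3s2)CC1c1ccc(O)cc1`: 106 umol/kg

In a functional assay on the whole organism (Hindlimb, strain albino) with Mus musculus as the target, in the maximal electroshock model, with a stated time of 0.5 h (a lower number here means that less compound is needed, a higher number that more compound is needed for the effect), the two measured compounds stand together: a 1.2-fold lower number from compound 1 to compound 2 (0.08 log units; within the scatter). That step concerns a group on a saturated ring carbon. Compound 3 `COc1ccc(C2CC(Nc3nc4ccccc4s3)=NN2C(C)=O)cc1O` differs from compound 1 elsewhere: hydrogen in place of chloro on an aromatic carbon. Among the measured compounds shown here, no measured step covers this change, so the data support no direction, and no step beyond the scatter is expected. The expected step is a 1.1-fold higher number from compound 1 to compound 3 (0.04 log units; within the scatter). The estimated value for compound 3 is 140 umol/kg, with an expected range of 60 umol/kg to 320 umol/kg.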

Compound 3, dose for half-maximal effect: 259 umol/kg
For compound 3 the middle estimate is 1.9-fold (0.27 log units) below the measured one; measured number inside the range.
By their numbers in this assay, from the lowest: compounds 2 and 1 (each within the scatter of the next); then compound 3.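

Chloro and hydrogen on this aromatic carbon are separable in this assay (a 2.0-fold higher number from compound 1 to compound 3 (0.31 log units; beyond the scatter)), a modest step but the only one in the series beyond the scatter. The change on the saturated ring carbon gave no such separation, so of the two places compared, only this one shows a readable difference, with less compound needed when chloro is present. Nothing on hand accounts for this step.

On these data alone, whether bromo, fluoro or methoxy at this carbon would match chloro remains open. So does whether the same step holds with the 4-hydroxyphenyl group of compound 2.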